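This account rests on a few compounds, and the source may have more. Where it says the series, first, only, none or still open, it means among the compounds named here.

Compound 1 `COc1cc2ncnc(Nc3ccc(NC(=O)c4cccc(C)c4)cc3)c2cc1OC`: 7500 nM
Compound 2 `COc1cc2ncnc(Nc3ccc(NC(=O)c4ccc(F)cc4)cc3)c2cc1OC`: 15000 nM

In a functional assay on HepG2 cells (Homo sapiens) for inhibition, read by MTT assay (a higher number here means a weaker inhibitor, a lower number a stronger inhibitor), compound 2 gives 15000 nM, within the scatter of compound 1 at 7500 nM. Compound 3 `COc1cc2ncnc(Nc3ccc(NC(=O)c4cccc(C(F)(F)F)c4)cc3)c2cc1OC`, not yet measured, shares the core of compound 2 and differs from it as follows: 3-(trifluoromethyl)phenyl in place of 4-fluorophenyl on a carbonyl carbon. For the measured compounds named here, the only measured step at this carbonyl carbon, a 2.0-fold higher number from compound 1 to compound 2 (0.30 log units; within the scatter), stayed within the scatter, so no clear shift is expected here. The estimated step is a 1.5-fold lower number from compound 2 to compound 3 (0.18 log units; within the scatter), and it is not expected to go beyond the scatter. Compound 3 is expected at 10000 nM, with an estimated range of 4000 nM to 25000 nM.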

Compound 3, half-maximal inhibitory concentration: 83000 nM
Estimate against measurement, compound 3: 8.3-fold (0.92 log units) below, and the stated range ends below it.
By their numbers in this assay, from the lowest: compounds 1 and 2 (each within the scatter of the next); then compound 3.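

At this carbonyl carbon, the choice of aryl group proves able to move the number in this assay: 3-(trifluoromethyl)phenyl in place of 4-fluorophenyl gives a step beyond the scatter (a 5.5-fold higher number from compound 2 to compound 3 (0.74 log units; beyond the scatter)), which the earlier pair did not show. Trifluoromethyl in place of methyl on an aromatic carbon, with the rest of the structure unchanged, also goes beyond the scatter (an 11-fold higher number from compound 1 to compound 3 (1.04 log units; beyond the scatter)). Nothing available accounts for either shift.

As far as these compounds go, it remains open whether an amine or a carboxylic acid on this aromatic ring would sit nearer compound 1 or compound 3.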